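The source may hold more compounds than are shown below. What is called first, only, known or untested is meant among the compounds shown, and "the series" means these compounds.

Three compounds share one core and differ in the group on an amine nitrogen: compound 1 `CON/C(=N\C1=NC(=O)C(=O)N1C(C)C)Nc1ccc(Cl)c(Cl)c1`, compound 2 `CCON/C(=N\C1=NC(=O)C(=O)N1C(C)C)Nc1ccc(Cl)c(Cl)c1` and compound 3 `CC(C)N1C(=O)C(=O)N=C1/N=C(\NCC(C)(C)C)Nc1ccc(Cl)c(Cl)c1`. All three were measured in an in vitro ADME assay on microsomes from liver (Homo sapiens) for metabolic stability, read by LC-MS; on this read-out lower numbers stand for a shorter-lived compound and higher numbers for a longer-lived compound. Compound 1 gives > 1 h, which is a limit of the assay and not a number. Compound 2 gives > 1 h, again a limit. Compound 3 gives > 1 h, also a limit, so compound 3 has no exact place on the scale. The whole set sits together: the limit of > 1 h in this assay, at which 3 of the 3 values shown sit.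

Compound 4 `CC(C)N1C(=O)C(=O)N=C1/N=C(\NCc1ccccc1)Nc1ccc(Cl)c(Cl)c1` has not yet been measured. It has phenyl in place of tert-butyl on a saturated chain carbon bound to an amine nitrogen, which turns neopentyl into benzyl: phenyl in place of tert-butyl on a saturated chain carbon bound to an amine nitrogen.

The closest measured changes, on that same amine nitrogen, are a step that the two limits leave unreadable from compound 1 to compound 3 and a step that the two limits leave unreadable from compound 2 to compound 3. Neither gives a size to carry over, and neither does a step that the two limits leave unreadable from compound 1 to compound 2. The expectation is therefore a weak one: no step beyond the scatter, and if anything a slightly shorter half-life. The estimated change is a step that the limit leaves unreadable from compound 3 to compound 4. The assay may well report only a limit again. For compound 4 the estimated half-life is 1.5 h, with an expected range from 0.7 h to 4 h.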

Compound 4, half-life: > 1 h
Compound 4 ended at the assay's limit (the forecaster's own chance of this, stated with the estimate: 65%); the middle value is on the limit's open side.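

Compound 4 gives > 1 h in this assay, which is a limit and not a number. No step from compound 1, compound 2 or compound 3 to compound 4 can therefore be read: the limit of > 1 h in this assay, at which 4 of the 4 values shown sit.

On these data alone, what stays open is the actual half-life of each of the four compounds, and whether methoxy, ethoxy, neopentyl or benzyl on the amine nitrogen changes it at all.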